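Fluoro for Amino on a Sulfanyl Purine Core

The source may report more compounds than this note shows. Statements on the series, on what has been measured and on what is new or still open speak of the compounds shown alone.

Measured compounds:
Compound 1, `CC(=O)OCCOn1cnc2c(Cl)nc(N)nc21`: > 500000 nM
Compound 2, `CC(=O)OCCOn1cnc2c(S)nc(N)nc21`: 4900 nM

Of the compounds shown here, two with a shared core have been tested in a functional assay on HEp-2 cells (Homo sapiens) for inhibition; a higher number here means a weaker inhibitor, a lower number a stronger inhibitor. Compound 1 reaches only a limit of the assay, > 500000 nM, which is not a number (the limit of > 500000 nM in this assay, at which 1 of the 2 values shown sits). For the measured compounds named here, compound 2 gives 4900 nM, the only real number among the values. Going by the values given here, the single measured step, an at least 100-fold lower number from compound 1 to compound 2 (2.00 log units; beyond the scatter), concerns the sulfanyl group and a different carbon of the core.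

Compound 3, `CC(=O)OCCOn1cnc2c(S)nc(F)nc21`, is not yet measured. It differs from compound 2 in one place: fluoro in place of amino on an aromatic carbon. The amino group that leaves is one hydrogen-bond donor and one hydrogen-bond acceptor, the fluoro that enters is neither. Among the compounds with values here, no measured step covers this exchange, so the only guide is the size of the one step seen, which is large. A step toward a higher number is expected, a 3.1-fold higher number from compound 2 to compound 3 (0.49 log units; beyond the scatter), with wide uncertainty. In this assay compound 3 is estimated at 15000 nM, between 3000 nM and 100000 nM.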

Compound 3, half-maximal inhibitory concentration: > 500000 nM
Compound 3: a limit, no number; the forecaster's own chance of this, stated with the estimate: 20%; at least 33-fold (1.52 log units) between middle value and limit.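

Compound 3 gives > 500000 nM in this assay, which is a limit of the assay and not a number. Fluoro in place of amino gives an at least 100-fold higher number from compound 2 to compound 3 (2.00 log units; beyond the scatter), so the carbon between two ring nitrogen atoms matters too, and the sulfanyl group alone does not keep a measurable value once the amino group has gone. Among the compounds shown, only compound 2 carries both sulfanyl and amino and only compound 2 gives a real number, while replacing either group ends at the same ceiling: the limit of > 500000 nM in this assay, at which 2 of the 3 values shown sit.

The compounds shown leave open whether a methylamino group, a hydroxyl group or a plain hydrogen on this carbon would keep a value close to that of compound 2, which would help separate what the amino group contributes from the simple loss of its hydrogen-bond donor and acceptor. As far as these compounds go, since compound 3 stops at a limit, the full size of this step also stays unknown, and it can only be read as a lower bound.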